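Furan-3-yl for Naphthalen-1-yl: Cytotoxicity Outlook for Compound 4

This account rests on a few compounds, and the source may have more. Where it says the series, first, only, none or still open, it means among the compounds named here.

Compound 1, `CC(C)N(Cc1cccc(OCCCCCC(=O)O)c1)C(=O)c1ccc(-c2cccc3ccccc23)cc1`, in an ADME assay on HepG2 cells (Homo sapiens) for cytotoxicity, read by CellTiter-Glo and resazurin assay, with a stated time of 72 h; a lower number here means that less compound is needed, a higher number that more compound is needed for the effect: > 26000 nM, a limit of the assay.
Compound 2, `CC(C)N(Cc1cccc(OCCCCCC(=O)O)c1)C(=O)c1ccc(-c2cccc(S(C)(=O)=O)c2)cc1`, in this assay: > 26000 nM, a limit of the assay.
Compound 3, `CCOC(=O)CCCCCOc1cccc(CN(C(=O)c2ccc(-c3cccc4ccccc34)cc2)C(C)C)c1`, in this assay: > 26000 nM, a limit of the assay.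

Compound 3 stands at the limit of > 26000 nM in this assay, at which 3 of the 3 values shown sit, so no number is known for it, only that limit. The two measured steps, a step that the two limits leave unreadable from compound 1 to compound 2 and a step that the two limits leave unreadable from compound 1 to compound 3, both run between limits and their size cannot be read. Compound 4 is `CCOC(=O)CCCCCOc1cccc(CN(C(=O)c2ccc(-c3ccoc3)cc2)C(C)C)c1`. It differs from compound 3 by furan-3-yl in place of naphthalen-1-yl on an aromatic carbon.

Going by the values given here, no measured step touches this exchange, and the steps that exist give no readable size, so nothing in the data points to a change beyond the scatter in either direction. The value for compound 4 in this assay is therefore expected to sit again at the limit, with a small chance of a readable number; the estimate for compound 4 is 30000 nM, ranging from 10000 nM to 100000 nM. That estimate means an expected step that the limit leaves unreadable from compound 3 to compound 4, reckoned against the limit of compound 3.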

Compound 4, half-maximal effective concentration: > 26000 nM
Compound 4: only a limit was reported; the forecaster's own chance of this, stated with the estimate: 80%; the middle value does not contradict the limit.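

In this assay compound 4 gives > 26000 nM, which is a limit and not a number, so the step from compound 3 to compound 4 cannot be read. The compounds shown leave open what concentration would reach the half-maximal effect for any of them, since all share one result: the limit of > 26000 nM in this assay, at which 4 of the 4 values shown sit.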